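A few compounds are considered here, and "the series" means these few. Any claim that something is new, unique, unknown or untested is made for them only; others in the source may bear on it.

Measured so far in a functional assay on CHO cells for positive allosteric modulation of metabotropic glutamate receptor 2 (Homo sapiens), read by scintillation counting and GTPgammaS binding, with a stated time of 30 min; on this read-out lower numbers stand for an effect already at smaller amounts and higher numbers for an effect only at larger amounts of compound:

Compound 1 `CC(C)CCn1ccc(-c2ccc(Oc3ccccc3)cc2)c(C#N)c1=O` gives 42 nM.
Compound 2 `CC(C)CCn1ccc(-c2ccc(Oc3ccncc3)cc2)c(C#N)c1=O` gives 550 nM.
Compound 3 `Cc1cc(Oc2ccc(-c3ccn(CCC(C)C)c(=O)c3C#N)cc2)ccn1` gives 447 nM.

Compound 3 stands second highest of the three numbers, with compound 2 nearest and compound 1 furthest. The nearer gap is a 1.2-fold lower number from compound 2 to compound 3 (0.09 log units; within the scatter), so these two compounds cannot be told apart. The further gap is an 11-fold higher number from compound 1 to compound 3 (1.03 log units; beyond the scatter), and the parallel step a 13-fold higher number from compound 1 to compound 2 (1.12 log units; beyond the scatter) is of the same kind: both swap the phenyl on the oxygen for a pyridin-4-yl or 2-methylpyridin-4-yl, and both raise the number clearly.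

Compound 4 `Cc1cc(Oc2ccc(-c3ccn(CC4CC4)c(=O)c3C#N)cc2)ccn1` differs from compound 3 at another place: cyclopropyl in place of isobutyl on a saturated chain carbon bound to an aromatic nitrogen. None of the three measured steps touches this chain on the nitrogen; all three concern the group on the oxygen. Among the measured compounds shown here, there is thus no measured step to lean on, and the expected step in this assay is a 1.0-fold higher number from compound 3 to compound 4 (0.00 log units; within the scatter), that is, no change beyond the scatter. Compound 4 is therefore estimated at 450 nM, with a range from 150 nM to 1400 nM.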

Compound 4, half-maximal effective concentration: 832 nM
Beside the measured number, compound 4's estimate is 1.8-fold (0.27 log units) below it; the range from low to high includes it.
By their numbers in this assay, from the lowest: compound 1; then compounds 3, 2 and 4 (each within the scatter of the next).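

Among the compounds shown here, the chain on the nitrogen, which none of the earlier steps touched, can be changed here: with cyclopropyl in place of isobutyl, or isopentyl becoming cyclopropylmethyl when cut one bond further out, this assay gives a 1.9-fold higher number from compound 3 to compound 4 (0.27 log units; within the scatter). So this change, which removes one carbon overall and adds a three-membered ring, cannot be told from the scatter, at least with the 2-methylpyridin-4-yl group on the oxygen. No measurement shown here explains this result.

Going by these compounds, whether the same swap would behave alike with the phenyl on the oxygen, as in compound 1, remains open. Also open, on these data alone, is how this position would respond to a longer chain such as n-hexyl, or to a chain ending in an amine or a carboxylic acid.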